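Pyrrole for Pyridine on the Anilide Ring

The compounds below may be only part of what the source reports. "The series", "measured", "known", "first", "only" and "open" are said of these compounds alone.

Measured compounds:
compound 1, `O=C(Nc1ccc(-c2cscn2)cc1)C1CCCN(Cc2cccc(F)c2F)C1`, 10000 nM
compound 2, `O=C(Nc1ccc(-c2cscn2)cc1)C1CCCN(Cc2cccc(C(F)(F)F)c2)C1`, a limit
compound 3, `O=C(Nc1ccc(-c2ccncc2)cc1)C1CCCN(Cc2ccc(F)c(F)c2)C1`, 1180 nM

In a functional assay on A-375 cells (Homo sapiens) for activation, with a stated time of 3 days (a higher number here means that more compound is needed for the effect, a lower number that less compound is needed), compound 3 gives 1180 nM, the lowest of the two numbers shown. Compound 1 gives 10000 nM in this assay, a gap beyond the scatter. For compound 2 this assay returns only a limit, > 20000 nM, and the limit of > 20000 nM in this assay, at which 1 of the 3 values shown sits, marks that one of the three values sits there. Within the data shown here, the one measured step, an at least 2.0-fold higher number from compound 1 to compound 2 (0.30 log units; that floor lies within the scatter), concerns the benzyl substituent on the ring nitrogen, not the heteroaryl group.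

Compound 4, `O=C(Nc1ccc(-c2cc[nH]c2)cc1)C1CCCN(Cc2ccc(F)c(F)c2)C1`, differs from compound 3 by 1H-pyrrol-3-yl in place of pyridin-4-yl on an aromatic carbon. Among the measured compounds shown here, no measured step bears on this change, so the expected step in this assay rests on the starting point alone. Compound 4 is expected to give 2500 nM, between 600 nM and 10000 nM. The step of a 2.1-fold higher number from compound 3 to compound 4 (0.33 log units; beyond the scatter) expected here is a modest weakening, not far beyond the scatter.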

Compound 4, half-maximal effective concentration: 2610 nM
For compound 4 the middle estimate is 1.0-fold (0.02 log units) below the measured one; low and high end bracket the measured number.
By their numbers in this assay, from the lowest: compound 3; then compound 4; then compound 1. At a limit, above all of these: compound 2.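

Among these compounds, until now the only measured step concerned the benzyl substituent on the ring nitrogen, so this is the first reading of the group para to a large group on the six-membered aromatic ring of carbon only. In this assay the swap to 1H-pyrrol-3-yl from pyridin-4-yl gives a 2.2-fold higher number from compound 3 to compound 4 (0.34 log units; beyond the scatter) and so costs only a modest amount. The position therefore accepts a five-membered aromatic ring with a hydrogen-bond donor in place of a six-membered one with a hydrogen-bond acceptor, and compound 4 still returns a measured number rather than a limit.

Ring size and the donor-for-acceptor exchange change together here, so a plain phenyl ring or 1-methyl-1H-pyrrol-3-yl would be needed to tell them apart. Nothing shown gives a measured reason for this step.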